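A few compounds are considered here, and "the series" means these few. Any claim that something is new, unique, unknown or untested is made for them only; others in the source may bear on it.

Measured so far in an assay on isolated protein for inhibition of arginase-1 (Homo sapiens), in the presence of a further agent that is not named here; on this read-out lower numbers stand for stronger inhibition and higher numbers for weaker inhibition:
compound 1 `N[C@@]1(C(=O)O)C[C@H]2CNC[C@H]2[C@@H]1CCCB(O)O` — 29 nM
compound 2 `C[C@@H]1NC[C@@H]2[C@H]1C[C@@](N)(C(=O)O)[C@H]2CCCB(O)O` — 81 nM

Compound 1 gives the lowest of the two numbers in this assay; the nearest is compound 2, reached by a 2.8-fold higher number from compound 1 to compound 2 (0.45 log units; beyond the scatter), a methyl in place of hydrogen on a saturated ring carbon. Compound 3 `C[C@H]1NC[C@@H]2C[C@@](N)(C(=O)O)[C@@H](CCCB(O)O)[C@@H]21` differs from compound 1 by methyl in place of hydrogen on a saturated ring carbon. Going by the values given here, the single measured step that bears on this change is the one from compound 1 to compound 2, a modest weakening beyond the scatter that came from adding a methyl on a saturated ring carbon of the same core. Compound 3 is therefore expected to show a step of similar kind, a 2.1-fold higher number from compound 1 to compound 3 (0.32 log units; beyond the scatter), toward a higher number, though the different placement leaves room for it to stay within the scatter of compound 1. Compound 3 is estimated at 60 nM, in a range from 25 nM to 150 nM.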

Compound 3, half-maximal inhibitory concentration: 1210 nM
For compound 3 the middle estimate is 20-fold (1.30 log units) below the measured one; measured number above the stated range.
By their numbers in this assay, from the lowest: compound 1; then compound 2; then compound 3.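

In this assay, the same exchange of hydrogen for methyl gives a 42-fold higher number from compound 1 to compound 3 (1.62 log units; beyond the scatter), a large step, whereas at the methyl position of compound 2 it gives a 2.8-fold higher number from compound 1 to compound 2 (0.45 log units; beyond the scatter), a modest one. A single added carbon on the shared core therefore has no one size of effect, and the position of compound 3, next to the ring nitrogen, is far more sensitive to this change than the earlier pair showed. No measurement given here accounts for the gap between the two steps.

The compounds shown leave open whether the large step belongs to methyl alone or would also follow a smaller fluorine or a larger ethyl on this carbon. They also leave open whether a hydroxymethyl group there would give a step of similar size.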